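The source may report more compounds than this note shows. Statements on the series, on what has been measured and on what is new or still open speak of the compounds shown alone.

Measured in a functional assay on SK-OV-3 cells (Homo sapiens) for antiproliferative activity, read by MTT assay, with a stated time of 72 h; a lower number here means a stronger inhibitor, a higher number a weaker inhibitor:
- compound 1 `CC(C)c1cccc(NC(=O)CCc2cccc3c2B(O)OC3)c1`: 510 nM
- compound 2 `COc1ccc(-c2cccc(NC(=O)CCc3cccc4c3B(O)OC4)c2)cc1`: 48 nM
- compound 3 `O=C(CCc1cccc2c1B(O)OC2)Nc1cccc(-c2cccc(OC(F)(F)F)c2)c1`: 460 nM

Compound 3 stands within the scatter of compound 1, and both lie well above compound 2, beyond the scatter. The next structure is compound 4 `CSc1cccc(-c2cccc(NC(=O)CCc3cccc4c3B(O)OC4)c2)c1`, not yet measured in this assay. The change is methylsulfanyl in place of trifluoromethoxy on an aromatic carbon, meta to a large group.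

For the measured compounds named here, no measured step covers this exchange directly. The only one available is an 11-fold lower number from compound 1 to compound 2 (1.03 log units; beyond the scatter), a large step made by putting 4-methoxyphenyl in place of isopropyl. It bears only loosely on the change here. Compound 3 also carries an aromatic ring in place of isopropyl, yet compound 3 at 460 nM does not share the low number of compound 2 at 48 nM. The group on that ring, or its place there, may therefore matter, though these few compounds cannot separate the two. A step towards a lower number is expected in this assay, much smaller than the one from isopropyl to 4-methoxyphenyl. The expected change is a 2.3-fold lower number from compound 3 to compound 4 (0.36 log units; beyond the scatter). For compound 4 the estimated value is 200 nM, with an expected range from 60 nM to 600 nM.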

Compound 4, half-maximal inhibitory concentration: 150 nM
Compound 4: middle estimate off by 1.3-fold (0.12 log units), on the high side; measured number inside the range.
By their numbers in this assay, from the lowest: compound 2; then compound 4; then compounds 3 and 1 (each within the scatter of the next).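

In this assay, for the compounds shown here, methylsulfanyl in place of trifluoromethoxy on an aromatic carbon, meta to a large group, gives a 3.1-fold lower number from compound 3 to compound 4 (0.49 log units; beyond the scatter), so this exchange on the outer ring moves the number beyond the scatter while the rest of the structure stays the same, something the earlier compounds could only hint at. The new compound also gives the series a second aryl example that clearly separates from the isopropyl starting point, with a 3.4-fold lower number from compound 1 to compound 4 (0.53 log units; beyond the scatter), though it does not reach the level of the 4-methoxyphenyl compound, as a 3.1-fold higher number from compound 2 to compound 4 (0.49 log units; beyond the scatter) shows, so the outcome of the aryl exchange depends on what that ring carries, with compound 3 as the example that stays within the scatter of compound 1. Nothing measured here accounts for these steps.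

Going by these compounds, whether the remaining gap to compound 2 comes from the group itself or from its place on the ring stays open, since 3-(methylsulfanyl)phenyl and 4-methoxyphenyl differ in both. Also open, on these data alone, is how an amine or a carboxylic acid at this position would read in this assay.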